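Tert-butyl for benzyl on the fused core

The source may report more compounds than this note shows. Statements on the series, on what has been measured and on what is new or still open speak of the compounds shown alone.

Three compounds have numbers in a functional assay on HT-29 cells (Homo sapiens) for cytotoxicity, read by sulforhodamine B assay, with a stated time of 48 h; a lower number here means a stronger inhibitor of growth, a higher number a weaker inhibitor of growth. Compound 1 `C=CC[C@@]12C[C@@H](C(=O)OC)N3[C@@H]1N(C(=N)C31CCCCC1)c1ccccc12` gives 22400 nM. Compound 2 `C=CC[C@@]12C[C@@H](C(=O)OC)N3[C@@H]1N(C(=N)[C@]3(Cc1ccccc1)N1CCCC1)c1ccc(Br)cc12` gives 7470 nM. Compound 3 `COC(=O)[C@@H]1C[C@@]2(CC=C(C)C)c3ccccc3N3C(=N)[C@H](Cc4ccccc4)N1[C@H]32` gives 20200 nM. Compound 3 stands second highest of the three; its nearest neighbour is compound 1, whose number sits within the scatter of that of compound 3, so no order between the two can be read. Its furthest neighbour is compound 2, whose number is lower by more than the scatter; compound 2 also differs from compound 3 in several places at once, so the gap cannot be tied to any single change.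

Compound 4 `COC(=O)[C@@H]1C[C@@]2(CC=C(C)C)c3ccccc3N3C(=N)[C@H](C(C)(C)C)N1[C@H]32` has not been measured. It differs from compound 3 in one place: tert-butyl in place of benzyl on a saturated ring carbon. Among the measured compounds shown here, no measured pair in this set isolates a change of this kind, so there is nothing here to anchor the size of the step. On the evidence of compound 3 with 20200 nM and the flat spread of compounds 1 and 3, the step from compound 3 to compound 4 is expected to be small, a 1.2-fold higher number from compound 3 to compound 4 (0.09 log units; within the scatter), with no direction beyond the scatter. Compound 4 is therefore estimated at 25000 nM, with a range from 8000 nM to 70000 nM.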

Compound 4, concentration for 50% growth inhibition: > 100000 nM
Compound 4: no number, only a limit; the forecaster's own chance of this, stated with the estimate: 15%; middle value at least 4.0-fold (0.60 log units) away from the limit.
By their numbers in this assay, from the lowest: compound 2; then compounds 3 and 1 (each within the scatter of the next). At a limit, above all of these: compound 4.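

In this assay compound 4 gives > 100000 nM, which is a limit of the assay and not a number. Among the compounds shown here, the change of tert-butyl in place of benzyl on a saturated ring carbon gives an at least 4.9-fold higher number from compound 3 to compound 4 (0.69 log units; beyond the scatter); this is the first one-place step, and it shows that growth inhibition responds to the group carried at this position of the five-membered non-aromatic ring with 2 nitrogen, which the earlier compounds, differing in several places at once, could not show. The step is bounded on one side only, and its full size cannot be read: the limit of > 100000 nM in this assay, at which 1 of the 4 values shown sits.

With only benzyl and tert-butyl compared at this carbon, the data do not separate the loss of the six-membered aromatic ring from the change in heavy atoms and branching. From the compounds shown here alone, a cyclohexylmethyl group, which keeps a ring but not an aromatic one, or an isobutyl group, which puts a carbon chain between the branch and the ring carbon, would help to tell these apart, and whether any group here improves on benzyl remains open.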